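Nucleoside series in BJ cells: ethynyl to thiophen-3-yl

The source may report more compounds than this note shows. Statements on the series, on what has been measured and on what is new or still open speak of the compounds shown alone.

Measured so far:
- compound 1 `O=c1[nH]cnc2c1c(-c1cccs1)cn2[C@@H]1O[C@H](CO)[C@@H](O)[C@H]1O`: in an ADME assay on BJ cells (Homo sapiens), read by MTT assay, with a stated time of 72 h (on this read-out higher numbers stand for weaker inhibition and lower numbers for stronger inhibition), compound 1 gives > 100000 nM, a limit of the assay and not a number.
- compound 2 `Cc1ncnc2c1c(-c1cc3ccccc3o1)cn2[C@@H]1O[C@H](CO)[C@@H](O)[C@H]1O`: in this assay compound 2 gives 93900 nM.
- compound 3 `C#Cc1cn([C@@H]2O[C@H](CO)[C@@H](O)[C@H]2O)c2nc(C)nc(N)c12`: in this assay compound 3 gives > 100000 nM, again a limit of the assay and not a number.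

Compound 3 therefore stands at the top edge of what this assay can report; nothing places it relative to compound 1, and only compound 2 supplies a number, which itself sits close to that edge. Two of the three values shown are limits (the limit of > 100000 nM in this assay, at which 2 of the 3 values shown sit). Among the compounds with values here, no pair of measured compounds differs in a single place, so no measured step is available to calibrate the next change.

Compound 4 `Cc1nc(N)c2c(-c3ccsc3)cn([C@@H]3O[C@H](CO)[C@@H](O)[C@H]3O)c2n1` is the compound still to be measured. Relative to compound 3 the change is thiophen-3-yl in place of ethynyl on an aromatic carbon. Within the data shown here, with the whole series at or near the assay limit, and with no measured step to suggest that any substituent at this position moves the read-out, the expectation for compound 4 is a step of no size beyond the scatter, a number no higher from compound 3 to compound 4 (the limit leaves the size open), most likely reported again as a limit. The estimate for compound 4 in this assay is 100000 nM, with a range from 40000 nM to 250000 nM.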

Compound 4, half-maximal inhibitory concentration: > 100000 nM
Compound 4: only a limit was reported; the forecaster's own chance of this, stated with the estimate: 70%; the middle value sits exactly at the limit.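

No step from compound 3 to compound 4 can be read in this assay, since both results are limits of the assay and not numbers: the limit of > 100000 nM in this assay, at which 3 of the 4 values shown sit.

The compounds shown leave open whether thiophen-3-yl in place of ethynyl on the shared core changes the read-out at all.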